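A few compounds are considered here, and "the series" means these few. Any claim that something is new, unique, unknown or untested is made for them only; others in the source may bear on it.

In an assay on isolated protein for inhibition of tyrosine-protein kinase receptor UFO (Homo sapiens), read by FRET and Z'-LYTE, with a stated time of 1.5 h (a lower number here means a stronger inhibitor, a higher number a weaker inhibitor), compound 1 `CCc1ccc2c(c1)c(=O)c(C(=O)Nc1ccc(Oc3ncnc4[nH]cc(-c5ccccc5)c34)c(C)c1)c(C)n2C` gives 1120 nM, and compound 2 `Cc1c(C(=O)Nc2ccc(Oc3ncnc4[nH]cc(-c5ccccc5)c34)c(F)c2)c(=O)c2cc(C3CC3)ccc2n1C` gives 230 nM. Compound 2 holds the lowest number of the two measured compounds; compound 1, its only neighbor, sits higher, and that gap lies beyond the usual scatter. Compound 3 `Cc1c(C(=O)Nc2ccc(Oc3ncnc4[nH]cc(-c5ccccc5)c34)c(F)c2)c(=O)c2cc(OC(F)(F)F)ccc2n1C` differs from compound 2 in one place: trifluoromethoxy in place of cyclopropyl on an aromatic carbon. Within the data shown here, no measured pair shows this kind of exchange, so its effect is unknown from these data. He expects a small step from compound 2 to compound 3 in this assay, a 1.5-fold higher number from compound 2 to compound 3 (0.18 log units; within the scatter), toward a somewhat higher number, possibly within the scatter. Compound 3 is estimated at 350 nM, between 120 nM and 1000 nM.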

Compound 3, half-maximal inhibitory concentration: 74 nM
Estimate against measurement, compound 3: 4.7-fold (0.67 log units) above; measured number outside the range, below it.
By their numbers in this assay, from the lowest: compound 3; then compound 2; then compound 1.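

Trifluoromethoxy in place of cyclopropyl on this aromatic carbon gives a 3.1-fold lower number from compound 2 to compound 3 (0.49 log units; beyond the scatter) in this assay. This shows that the number responds to the group at this place on the shared core, and that a ring is not needed there. No measurement given here accounts for the step. From the compounds shown here alone, how a methoxy group, a trifluoromethyl group or an amine would read on this carbon stays open. So does whether the oxygen or the fluorine atoms of the new group carry the step.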